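Replacing One Fluorine with a Much Larger Group

The source may report more compounds than this note shows. Statements on the series, on what has been measured and on what is new or still open speak of the compounds shown alone.

Of the compounds shown here, three have been measured so far in a functional assay on DU-145 cells (Homo sapiens) for cytotoxicity, read by trypan blue exclusion, with a stated time of 96 h; a higher number here means a weaker inhibitor, a lower number a stronger inhibitor. Compound 1 `O=S(=O)(/C=C/c1ccccc1)Nc1ccccc1` gives 10000 nM, and compound 2 `COc1cc(OC)c(/C=C/S(=O)(=O)Nc2ccc(F)c(N)c2)c(OC)c1` gives 10000 nM. Compound 3 `COc1cc(OC)c(/C=C/S(=O)(=O)Nc2ccc(OC)c(F)c2)c(OC)c1` gives 200 nM, the lowest of the three numbers and well beyond the scatter from both of the others.

The next compound to be tested is compound 4 `COC(=O)C(Nc1cc(NS(=O)(=O)/C=C/c2c(OC)cc(OC)cc2OC)ccc1OC)c1ccccc1`. It differs from compound 3 in one place: a group of 12 heavy atoms (9 carbon, 1 nitrogen, 2 oxygen; one six-membered aromatic ring of carbon only) in place of one fluorine atom, on an aromatic carbon. A group with its own six-membered aromatic ring takes the place of one fluorine atom on an aromatic carbon, ortho to a methoxy group.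

Within the data shown here, only one measured step bears on this change: a 50-fold lower number from compound 2 to compound 3 (1.70 log units; beyond the scatter). That large step came when 3-fluoro-4-methoxyphenyl took the place of 3-amino-4-fluorophenyl on a sulfonamide nitrogen. It shows that the number can move a long way with the groups on this ring, but it involves a different exchange. Among the measured compounds shown here, no measured compound carries a group this large, so the data favour no direction. No step beyond the scatter is therefore expected in this assay, and the estimated step is a 1.5-fold higher number from compound 3 to compound 4 (0.18 log units; within the scatter), with wide uncertainty on either side. The estimate for compound 4 is 300 nM, with an expected range of 30 nM to 3000 nM.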

Compound 4, half-maximal inhibitory concentration: 2500 nM
For compound 4 the middle estimate is 8.3-fold (0.92 log units) below the measured one; the range from low to high includes it.
By their numbers in this assay, from the lowest: compound 3; then compound 4; then compounds 1 and 2 (each within the scatter of the next).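

In this assay, putting the large group in place of the fluorine gives a 13-fold higher number from compound 3 to compound 4 (1.10 log units; beyond the scatter), so what sits at this aromatic carbon, ortho to a methoxy group, clearly matters to the read-out. Among these compounds, the earlier step exchanged two groups on this ring at once, whereas this one changes a single group while the methoxy group and the rest of the molecule stay the same, giving the first reading for this position alone. The entering group brings several new features together, including a six-membered aromatic ring, a nitrogen, two oxygens and a double bond outside the ring, and no measurement shown here explains the rise or ties it to any one of them.

On these data alone, with only a fluorine and this much larger group to compare, it remains open how the number would respond to something of intermediate size, such as a methyl group, a hydroxyl group or a short alkyl chain. As far as these compounds go, it also remains open whether a pared-down form of the large group, such as a plain benzyl group or a carboxylic acid in place of its ester, would give a number closer to that of compound 3.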